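Swapping a Para Methyl for Chloro

This account rests on a few compounds, and the source may have more. Where it says the series, first, only, none or still open, it means among the compounds named here.

compound 1 `COc1ccc(C2=NN(c3nc(-c4ccc(Br)cc4)cs3)C(c3ccc4c(c3)OCCO4)C2)cc1`: 2520 nM
compound 2 `Cc1ccc(C2=NN(c3nc(-c4ccc(Br)cc4)cs3)C(c3ccc4c(c3)OCCO4)C2)cc1`: 1680 nM

In a functional assay on B16-F10 cells (Mus musculus) for antiproliferative activity, read by MTT assay, with a stated time of 48 h (on this read-out higher numbers stand for weaker inhibition and lower numbers for stronger inhibition), compound 2 gives 1680 nM, the smaller of the two numbers, while compound 1 gives 2520 nM; the step of a 1.5-fold lower number from compound 1 to compound 2 (0.18 log units; within the scatter) lies within the scatter, so the two cannot be told apart. Compound 3 `Clc1ccc(C2=NN(c3nc(-c4ccc(Br)cc4)cs3)C(c3ccc4c(c3)OCCO4)C2)cc1` differs from compound 2 by chloro in place of methyl on an aromatic carbon. For the measured compounds named here, the only measured step at this position, a 1.5-fold lower number from compound 1 to compound 2 (0.18 log units; within the scatter), was within the scatter, and nothing measured points to a larger effect for chloro. The expected step of a 1.1-fold lower number from compound 2 to compound 3 (0.05 log units; within the scatter) is therefore no change beyond the scatter. Compound 3 is estimated at 1500 nM, with a range from 700 nM to 3500 nM.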

Compound 3, half-maximal inhibitory concentration: 2150 nM
For compound 3 the middle estimate is 1.4-fold (0.16 log units) below the measured one, within the range that was stated.
By their numbers in this assay, from the lowest: compounds 2, 3 and 1 (each within the scatter of the next).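

In this assay, chloro cannot be told apart from methyl (a 1.3-fold higher number from compound 2 to compound 3 (0.11 log units; within the scatter)) or from methoxy (a 1.2-fold lower number from compound 1 to compound 3 (0.07 log units; within the scatter)). All three groups on this aromatic carbon, para to a large group, now lie within the scatter of one another, so this change shows no measurable effect here. Nothing available explains this result. Going by these compounds, whether an amine, a carboxylic acid or a longer chain at this position would give a step beyond the scatter remains open. So does whether chloro and methyl would still match with a different group elsewhere on the shared core.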